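A few compounds are considered here, and "the series" means these few. Any claim that something is new, unique, unknown or untested is made for them only; others in the source may bear on it.

Measured so far in a functional assay on U-251 cells (Homo sapiens) for antiproliferative activity, read by sulforhodamine B assay, with a stated time of 48 h, tested at 50 uM; on this read-out lower numbers stand for less inhibition and higher numbers for more inhibition at the one concentration tested (going by the name of the read-out):
- compound 1, `CC1=CC[C@H](C(C)C)c2cc(C)c(OC(=O)c3ccc(C)cc3)cc21`: 67.7%
- compound 2, `COc1cccc(C(=O)Oc2cc3c(C)ccc(C(C)C)c3cc2C)c1`: "not active" (no number reported), reported without a number
- compound 3, `Cc1cc2c(C(C)C)ccc(C)c2cc1OC(=O)c1ccc([N+](=O)[O-])cc1`: 100%

Compound 1 is the lower of the two numbers in this assay. Compound 3 stands a good way above it, a gap beyond the scatter, while compound 2 is recorded only as inactive, with no figure to place it.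

Compound 4, `CC1=CC[C@H](C(C)C)c2cc(C)c(OC(=O)c3cccc(C)c3)cc21`, is the next step from compound 1 and differs from it in one place: 3-methylphenyl in place of 4-methylphenyl on a carbonyl carbon. The two share the same atoms, joined differently, and no other part of the ester or of the core changes.

No measured pair in the set moves a methyl from one place on the aryl ring to another, so the size of this step cannot be taken from a shown step. With compound 1 at 67.7% and the change limited to shifting a methyl on the aryl ester, a modest fall in this assay is expected, though a result within the scatter of compound 1 is also possible. For compound 4 the expected value is 55% (range 25% to 80%), a step of a number 12.7 percentage points lower from compound 1 to compound 4 (beyond the scatter).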

Compound 4, a percentage reported as inhibition, at one concentration (the size of the read-out at that concentration, not a potency): 16.8%
Estimate against measurement, compound 4: 38.2 percentage points above; the measured number lies below the stated range.
By their numbers in this assay, from the lowest: compound 4; then compound 1; then compound 3.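

In this assay, where the methyl sits on the aryl ester has a large effect: a number 50.9 percentage points lower from compound 1 to compound 4 (beyond the scatter), with 3-methylphenyl in place of 4-methylphenyl on a carbonyl carbon and the same atoms throughout. Within the data shown here, this is the first step that can be read, and it shows that the read-out responds to the arrangement of this ring even when the shared core and the composition stay the same. No supporting measurement bears on the reason for this step, so it stands as an observation only.

As far as these compounds go, it remains open whether an amine or a carboxylic acid on this aryl ring would keep the level of compound 1 at 67.7%. A longer chain in place of the methyl also remains untested among the compounds shown, at either ring placement.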